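This account rests on a few compounds, and the source may have more. Where it says the series, first, only, none or still open, it means among the compounds named here.

Measured compounds:
compound 1 `C#Cc1c(-c2ccccc2)[nH]c2ccccc12` — 88%
compound 2 `Cn1c(-c2ccc(Cl)c(Cl)c2)cc2ccccc21` — 20%
compound 3 `c1ccc(Cn2c(-c3ccccc3)cc3ccccc32)cc1` — 0%

In an assay on isolated protein for inhibition of Aromatase (Homo sapiens), read by fluorescence, using NADPH, with a stated time of 30 min, tested at 50 uM (on this read-out lower numbers stand for less inhibition and higher numbers for more inhibition at the one concentration tested (going by the name of the read-out)), compound 2 stands second highest of the three numbers. Its nearest neighbour is compound 3, whose value of 0% lies beyond the scatter below it; the furthest is compound 1, whose value of 88% lies beyond the scatter above it. Compound 4 `Clc1ccc(-c2cc3ccccc3[nH]2)cc1Cl` has not yet been measured in this assay. It differs from compound 2 in one place: hydrogen in place of methyl on an aromatic nitrogen. Within the data shown here, no step between measured compounds follows this exact change, so the expected size rests on the whole set. Compound 1, which also bears hydrogen on its aromatic nitrogen, gives 88%, and both nitrogen-substituted compounds sit low. Compound 4 is therefore expected to rise beyond the scatter, by an estimated a number 30 percentage points higher from compound 2 to compound 4 (beyond the scatter). The estimate for compound 4 in this assay is 50%, within a range of 20% to 80%.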

Compound 4, a percentage reported as inhibition, at one concentration (the size of the read-out at that concentration, not a potency): 22.7%
Compound 4: middle estimate off by 27.3 percentage points, on the high side, and the stated range covers the measured number.
By their numbers in this assay, from the lowest: compound 3; then compounds 2 and 4 (each within the scatter of the next); then compound 1.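

In this assay, the step for hydrogen in place of methyl on the aromatic nitrogen is a number 2.7 percentage points higher from compound 2 to compound 4 (within the scatter). With the rest of the structure held constant, the two groups at this position therefore cannot be told apart on this read-out. Hydrogen on that nitrogen is thus not enough on its own to give a high number on this core. As far as these compounds go, it remains open whether a longer chain, an amine or a carboxylic acid on that nitrogen would read differently from methyl or hydrogen. Nothing available explains why this exchange leaves the two numbers within the scatter.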